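Closing the amine into a ring on compound 2

The source may report more compounds than this note shows. Statements on the series, on what has been measured and on what is new or still open speak of the compounds shown alone.

For the measured compounds named here, compound 2 `CCN(CC)Cc1cc(-c2ccccc2)n(Nc2ccnc3cc(Cl)ccc23)c1C` is the only member of this small set with a number to its name. In an ADME assay on K562 cells (Homo sapiens) for cytotoxicity, read by MTT assay (on this read-out lower numbers stand for stronger inhibition and higher numbers for weaker inhibition), compound 2 gives 3620 nM. Of its two companions, compound 1 `Cc1c(CN2CCCC2)cc(-c2ccc(Cl)cc2)n1Nc1ccnc2cc(Cl)ccc12` is recorded in this assay as "not determined" (no result reported), and compound 3 `CCN(CC)Cc1cc(C)n(Nc2ccnc3cc(Cl)ccc23)c1C` is recorded in this assay as "not determined" (no result reported), so compound 2 cannot be placed above or below anything; it stands alone as the single measured point.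

Compound 4 `Cc1c(CN2CCCC2)cc(-c2ccccc2)n1Nc1ccnc2cc(Cl)ccc12` is the next compound to be tested. It differs from compound 2 in one place: pyrrolidin-1-yl in place of diethylamino on a saturated chain carbon bound to an aromatic carbon. Going by the values given here, no pair of measured compounds shows what such a swap does in this assay, and the two amines are close relatives in what is counted for them. The change expected is a 1.0-fold lower number from compound 2 to compound 4 (0.01 log units; within the scatter), which is to say nothing beyond the scatter of this assay and with no direction favoured. Compound 4 is therefore estimated to give 3500 nM in this assay, within a range from 1500 nM to 8000 nM.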

Compound 4, half-maximal inhibitory concentration: 2920 nM
Compound 4: middle estimate off by 1.2-fold (0.08 log units), on the high side; measured number inside the range.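

In this assay, the step is a 1.2-fold lower number from compound 2 to compound 4 (0.09 log units; within the scatter), so compound 2 and compound 4 cannot be told apart in this read-out. For the compounds shown here, this is the first measured comparison at this position, and it shows that tying the two ethyl arms of the diethylamino group into the pyrrolidin-1-yl ring, with the heavy-atom count unchanged, leaves the cytotoxicity read-out within the scatter. Nothing available explains why the two amines read alike.

As far as these compounds go, whether a larger change on the same saturated chain carbon, such as a morpholine, a piperazine or a carboxylic acid in place of the amine, or a longer chain carrying the amine, would move the number remains open. This single pair also cannot show whether the same swap behaves alike on other versions of the shared core.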